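The source may report more compounds than this note shows. Statements on the series, on what has been measured and on what is new or still open speak of the compounds shown alone.

Among the measured compounds shown here, compound 1 `Clc1ccc(-c2nnc(-c3ccc(-n4cccc4)cc3)o2)cc1` is the only compound here with a number. In an ADME assay on Vero cells (Chlorocebus sabaeus) for cytotoxicity, read by MTT assay, with a stated time of 72 h (on this read-out lower numbers stand for stronger inhibition and higher numbers for weaker inhibition), compound 1 gives 253000 nM, and since no other number is shown, it stands alone, with nothing to be ranked against. Compound 2 `Cc1ccc(C)n1-c1ccc(C(=O)N/N=C/c2ccccc2[N+](=O)[O-])cc1` was also included, but in this assay compound 2 is recorded as "not determined" (no result reported), so it adds nothing to the comparison. Compound 3 `c1ccc(-c2nnc(-c3ccc(-n4cccc4)cc3)o2)cc1` is the compound still to be measured. It differs from compound 1 in one place: hydrogen in place of chloro on an aromatic carbon. For the measured compounds named here, no step between two measured compounds is available to guide a guess, so the expectation rests on the change being small, a single chlorine removed from a ring carbon. The step is expected to be a 1.2-fold higher number from compound 1 to compound 3 (0.07 log units; within the scatter), that is, none beyond the scatter, perhaps leaning toward a higher number. For compound 3 the estimated value in this assay is 300000 nM, with a range from 120000 nM to 750000 nM.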

Compound 3, half-maximal inhibitory concentration: 250000 nM
Beside the measured number, compound 3's estimate is 1.2-fold (0.08 log units) above it; low and high end bracket the measured number.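

In this assay the change from 4-chlorophenyl to phenyl gives a 1.0-fold lower number from compound 1 to compound 3 (0.01 log units; within the scatter) and so stays within the usual scatter of repeated measurements. On this aromatic carbon, para to a large group, chloro and hydrogen therefore cannot be told apart by this read-out, which could not be seen while compound 1 stood alone. The data shown offer no measurement that would explain this outcome.

Going by these compounds, whether the position stays just as undiscriminating with other groups, such as an amine, a methoxy group or a carboxylic acid, remains open. This single pair also says nothing about changes made elsewhere on the shared core.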